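The compounds below may be only part of what the source reports. "The series", "measured", "known", "first", "only" and "open" are said of these compounds alone.

Measured compounds:
compound 1, `Cc1cc(O)c(C2=NN(c3ccc(S(N)(=O)=O)cc3)C(c3ccccc3O)C2)cc1Cl`, 4640 nM
compound 2, `Cc1cc(O)c(C2=NN(c3ccc(S(N)(=O)=O)cc3)C(c3ccccc3Cl)C2)cc1Cl`, 3280 nM
compound 3, `Cc1cc(O)c(C2=NN(c3ccc(S(N)(=O)=O)cc3)C(/C=C/c3ccccc3)C2)cc1Cl`, 12300 nM

These three share a core and differ at one saturated ring carbon. In a functional assay on Hs-578T cells (Homo sapiens) for antiproliferative activity, with a stated time of 48 h (a higher number here means a weaker inhibitor of growth, a lower number a stronger inhibitor of growth), compound 3 gives the highest number of the three: a 2.7-fold higher number from compound 1 to compound 3 (0.42 log units; beyond the scatter) and a 3.8-fold higher number from compound 2 to compound 3 (0.57 log units; beyond the scatter), both beyond the scatter, whereas a 1.4-fold lower number from compound 1 to compound 2 (0.15 log units; within the scatter) stays within it.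

Compound 4, `COc1ccc(C2CC(c3cc(Cl)c(C)cc3O)=NN2c2ccc(S(N)(=O)=O)cc2)c(OC)c1OC`, has not yet been measured in this assay. It differs from compound 3 in one place: 2,3,4-trimethoxyphenyl in place of 2-phenylethenyl on a saturated ring carbon. The two steps that bear on it are those in which an aryl group at this carbon was exchanged for 2-phenylethenyl, each giving a modestly higher number, so the reverse move back to an aryl group is expected to give a modestly lower number. Whether the three methoxy groups shift the result further cannot be judged from compounds 1 to 3. The expected step is a 3.1-fold lower number from compound 3 to compound 4 (0.49 log units; beyond the scatter). Compound 4 is therefore estimated at 4000 nM, with a range from 1500 nM to 11000 nM.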

Compound 4, concentration for 50% growth inhibition: 2210 nM
Beside the measured number, compound 4's estimate is 1.8-fold (0.26 log units) above it; measured number inside the range.
By their numbers in this assay, from the lowest: compounds 4, 2 and 1 (each within the scatter of the next, the first and the last beyond it); then compound 3.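

In this assay, 2,3,4-trimethoxyphenyl at this saturated ring carbon gives the largest step yet seen away from 2-phenylethenyl (a 5.6-fold lower number from compound 3 to compound 4 (0.75 log units; beyond the scatter)), so all three aryl groups shown, in compound 1, compound 2 and compound 4, give lower numbers than the 2-phenylethenyl group of compound 3. The carbon also accepts this 12-atom aryl group without a loss: the step from the 2-chlorophenyl analogue (a 1.5-fold lower number from compound 2 to compound 4 (0.17 log units; within the scatter)) stays within the scatter, while the step from the 2-hydroxyphenyl analogue (a 2.1-fold lower number from compound 1 to compound 4 (0.32 log units; beyond the scatter)) lies beyond it. Nothing in the data offers an explanation for these differences.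

Which of the methoxy groups matter remains open, as a single methoxy group on the phenyl ring does not appear among these compounds. So does the outcome at this carbon with an amine, a carboxylic acid or a saturated alkyl chain in place of the aryl group.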